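Swapping a Cyclohexyl Ring for an Octyl Chain

This account rests on a few compounds, and the source may have more. Where it says the series, first, only, none or still open, it means among the compounds named here.

Three compounds share one core and differ only in the group attached to the five-membered aromatic ring. Compound 1 `O=C(NCc1ccc(-c2noc(CCC3CCCCC3)n2)cc1)[C@H]1NCC[C@@H]1O` carries a 2-cyclohexylethyl group, compound 2 `O=C(NCc1ccc(-c2noc(C3CCCCCC3)n2)cc1)[C@H]1NCC[C@@H]1O` a cycloheptyl group and compound 3 `O=C(NCc1ccc(-c2noc(C3CCCCC3)n2)cc1)[C@H]1NCC[C@@H]1O` a cyclohexyl group. In a physicochemical assay for solubility, at pH 7.4 (on this read-out lower numbers stand for lower solubility and higher numbers for higher solubility), compound 1 gives 26 ug/mL. For compound 2 the result is a limit of the assay, > 50 ug/mL. For compound 3 the result is likewise a limit, > 50 ug/mL. The measured steps are an at least 1.9-fold higher number from compound 1 to compound 2 (0.28 log units; that floor lies within the scatter) and an at least 1.9-fold higher number from compound 1 to compound 3 (0.28 log units; that floor lies within the scatter), while a step that the two limits leave unreadable from compound 2 to compound 3. Compound 3 therefore stands at the limit of > 50 ug/mL in this assay, at which 2 of the 3 values shown sit, so its true number is not known, only its floor.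

Compound 4 `CCCCCCCCc1nc(-c2ccc(CNC(=O)[C@H]3NCC[C@@H]3O)cc2)no1` is made from compound 3 by the change (octyl in place of cyclohexyl on an aromatic carbon). Going by the values given here, no measured step covers the exchange of a ring for an open chain, so the evidence is indirect: compound 1, whose group also lacks a direct ring attachment, sits below the limit reached by compound 3. On that basis compound 4 is expected to fall below the floor of compound 3, so that the estimated step is an at least 2.7-fold lower number from compound 3 to compound 4 (0.44 log units; beyond the scatter). The expected value for compound 4 is 18 ug/mL, most likely between 6 ug/mL and 50 ug/mL.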

Compound 4, solubility: 4 ug/mL
The estimate for compound 4 lay 4.5-fold (0.65 log units) above the measured number, outside the stated range (below it).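

In this assay, the open octyl chain gives a far lower number than either ring attached directly to this carbon of the five-membered aromatic ring: an at least 12-fold lower number from compound 3 to compound 4 (1.09 log units; beyond the scatter), and an at least 12-fold lower number from compound 2 to compound 4 (1.09 log units; beyond the scatter). These two steps are only minimum sizes because compound 2 and compound 3 each sit at a limit rather than at a true number: the limit of > 50 ug/mL in this assay, at which 2 of the 4 values shown sit. The third comparison has no such limit and gives a 6.5-fold lower number from compound 1 to compound 4 (0.81 log units; beyond the scatter), so compound 4 has the lowest number of the four and a chain that ends in a cyclohexyl ring, as in compound 1, stands apart from the fully open octyl chain.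

The step between compound 2 and compound 3 cannot be read, so any difference between the cycloheptyl and cyclohexyl rings stays hidden. The compounds shown also cannot separate the loss of the ring from the length of the chain, and a shorter chain such as butyl, or an octyl-length chain carrying an amine, would be needed to tell how far each of these counts at this position.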